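The source may report more compounds than this note shows. Statements on the series, on what has been measured and on what is new or still open speak of the compounds shown alone.

In an ADME assay on HepG2 cells (Homo sapiens) for cytotoxicity, read by luminescence, with a stated time of 72 h (on this read-out lower numbers stand for an effect already at smaller amounts and higher numbers for an effect only at larger amounts of compound), the three measured compounds read as follows.

Compound 1 `CCOC(=O)c1c(-c2cccc(OC)c2)[nH]c2cc(OC)c(F)cc2c1=O` gives > 21500 nM as a limit
Compound 2 `CCOC(=O)c1c(-c2cccc(OC(F)(F)F)c2)[nH]c2cc(OC)c(F)cc2c1=O` gives > 21500 nM as a limit
Compound 3 `CCOC(=O)c1c(-c2cccc(Cl)c2)[nH]c2cc(OC)c(F)cc2c1=O` gives > 21500 nM as a limit

Compound 3 has no exact value and stands only at a limit. The other two measured compounds also give only limits, so no order can be read among the three. The next compound, compound 4 `CCOC(=O)c1c(-c2cccc(Br)c2)[nH]c2cc(OC)c(F)cc2c1=O`, differs from compound 3 by bromo in place of chloro on an aromatic carbon, and the change counts as bromo in place of chloro on an aromatic carbon in full.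

Among the measured compounds shown here, three measured steps bear on this change. They are a step that the two limits leave unreadable from compound 1 to compound 2, a step that the two limits leave unreadable from compound 1 to compound 3 and a step that the two limits leave unreadable from compound 2 to compound 3, and none of them has a readable size. What they do show is a shared ceiling, as the limit of > 21500 nM in this assay, at which 3 of the 3 values shown sit, makes plain. All three substituents at this place, on an otherwise unchanged core, leave the read-out at that one limit.

The expected step is a step that the limit leaves unreadable from compound 3 to compound 4, and nothing beyond the usual scatter is anticipated, with no direction favoured. Compound 4 is therefore expected to give another limit in this assay rather than a number. The estimate for compound 4 is 22000 nM, with an expected range from 12000 nM to 40000 nM as its two ends.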

Compound 4, half-maximal effective concentration: > 21500 nM
Compound 4: only a limit was reported (the forecaster's own chance of this, stated with the estimate: 85%); the middle value lies beyond the limit too.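

In this assay no new step can be read between compound 4 and compound 1, compound 2 or compound 3, since all four give only a limit: the limit of > 21500 nM in this assay, at which 4 of the 4 values shown sit.

The compounds shown leave open how far each lies beyond that limit, and whether any other substituent at this place on the shared core would give a measurable number.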